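This account rests on a few compounds, and the source may have more. Where it says the series, first, only, none or still open, it means among the compounds named here.

Working notes on the series. Compound 1 `COC(=O)c1ccc(-c2cn(CC(=O)Nc3nc(C)cs3)nn2)cc1` carries a methoxycarbonyl group. In a functional assay on BMDM cells (Mus musculus, strain C57BL/6) for inhibition, with a stated time of 2 days (a higher number here means a weaker inhibitor, a lower number a stronger inhibitor), compound 1 shows only > 30000 nM, which is a limit of the assay and not a number (the limit of > 30000 nM in this assay, at which 1 of the 3 values shown sits). Compound 2 `COc1ccc(-c2cn(CC(=O)Nc3nc(C)cs3)nn2)cc1` gives 3890 nM in this assay. Within the data shown here, the only measured step in the set, an at least 7.7-fold lower number from compound 1 to compound 2 (0.88 log units; beyond the scatter), concerns this methoxy-for-methoxycarbonyl exchange. Compound 3 `Cc1csc(NC(=O)Cn2cc(-c3ccccc3Cl)nn2)n1` gives 1240 nM in this assay, the lowest of the two numbers shown; compound 2 sits above it beyond the scatter.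

Compound 4 `Cc1csc(NC(=O)Cn2cc(-c3ccc(Cl)cc3)nn2)n1` differs from compound 3 by 4-chlorophenyl in place of 2-chlorophenyl on an aromatic carbon. Among the measured compounds shown here, no measured step moves a chlorine around the ring, so the step from compound 1 to compound 2 bears only loosely on this change: it concerns a different group at a different position. With no direct evidence, the step of a 2.0-fold higher number from compound 3 to compound 4 (0.30 log units; within the scatter) is expected to be small, with a slight lean toward a higher number, and may well fall within the scatter. Compound 4 is therefore estimated at 2500 nM in this assay, within 800 nM to 8000 nM.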

Compound 4, half-maximal inhibitory concentration: 520 nM
Beside the measured number, compound 4's estimate is 4.8-fold (0.68 log units) above it, outside the stated range (below it).
By their numbers in this assay, from the lowest: compound 4; then compound 3; then compound 2. At a limit, above all of these: compound 1.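

The chlorine's place on the phenyl ring now proves to matter in this assay: with the same atoms, 4-chlorophenyl in place of 2-chlorophenyl gives a 2.4-fold lower number from compound 3 to compound 4 (0.38 log units; beyond the scatter) at this position of the shared core. Chloro in place of methoxy gives a 7.5-fold lower number from compound 2 to compound 4 (0.87 log units; beyond the scatter), so the group on the phenyl ring also counts, with chloro ahead of methoxy. Chloro in place of methoxycarbonyl gives an at least 57-fold lower number from compound 1 to compound 4 (1.76 log units; beyond the scatter), a step with only a bound on its size, as the value of compound 1 is a limit and not a number.

Still open, going by these compounds, is how an amine, a carboxylic acid or a longer chain in place of the chlorine of compound 4 would read in this assay. Nothing shown accounts for these steps.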